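The compounds below may be only part of what the source reports. "The series", "measured", "known", "first", "only" and "open" are said of these compounds alone.

In a functional assay on HT-29 cells (Homo sapiens) for antiproliferative activity, read by sulforhodamine B assay, with a stated time of 48 h (on this read-out lower numbers stand for stronger inhibition and higher numbers for weaker inhibition), three compounds have been measured:

Compound 1 `CCCC(=O)Nc1ccc(S(=O)(=O)Oc2ccccc2C(C)C)cc1` gives 4900 nM.
Compound 2 `CCCCCC(=O)Nc1ccc(S(=O)(=O)Oc2ccccc2C(C)C)cc1` gives 6400 nM.
Compound 3 `CCCCCC(=O)Nc1ccc(S(=O)(=O)Oc2ccccc2I)cc1` gives 13000 nM.

Compound 2 stands second highest of the three numbers in this assay. The step of a 1.3-fold higher number from compound 1 to compound 2 (0.12 log units; within the scatter) lies within the scatter, whereas a 2.0-fold higher number from compound 2 to compound 3 (0.31 log units; beyond the scatter) is a modest step beyond it, so compound 2 sits close to compound 1 and somewhat apart from compound 3.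

The untested compound 4 `CC(C)c1ccccc1OS(=O)(=O)c1ccc(NC(=O)CCCl)cc1` differs from compound 2 by chloro in place of propyl on a saturated chain carbon, two bonds along the chain from a carbonyl carbon. Among the measured compounds shown here, no measured step alters exactly this part of the structure. The step of a 1.3-fold higher number from compound 1 to compound 2 (0.12 log units; within the scatter) lengthened the saturated chain and stayed within the scatter, which suggests that the length of this chain matters little in this assay. The step of a 2.0-fold higher number from compound 2 to compound 3 (0.31 log units; beyond the scatter) concerned an aromatic carbon and does not bear on the chain. For the measured compounds named here, nothing among the measured compounds shows what a chloro at this place does.

The expectation for compound 4 is therefore a step of a 1.2-fold lower number from compound 2 to compound 4 (0.07 log units; within the scatter), with no clear direction and not beyond the scatter. Compound 4 is accordingly estimated at 5500 nM, within a range from 2000 nM to 15000 nM in this assay.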

Compound 4, half-maximal inhibitory concentration: 16000 nM
The estimate for compound 4 lay 2.9-fold (0.46 log units) below the measured number; the whole stated range lies below it.
By their numbers in this assay, from the lowest: compounds 1 and 2 (each within the scatter of the next); then compounds 3 and 4 (each within the scatter of the next).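

Among the compounds shown here, the terminal position of this chain is not as indifferent to change as the earlier compounds suggested: in this assay lengthening the chain gave only a 1.3-fold higher number from compound 1 to compound 2 (0.12 log units; within the scatter) and stayed within the scatter, whereas chloro in place of propyl gives a 2.5-fold higher number from compound 2 to compound 4 (0.40 log units; beyond the scatter) and so moves beyond it. The closest comparison is with methyl at the same place, where chloro gives a 3.3-fold higher number from compound 1 to compound 4 (0.51 log units; beyond the scatter) and the change is again beyond the scatter, so the shift does not depend on compound 2 as the reference and appears with a single atom exchanged at the chain end. No measurement shown here explains why chloro at this place goes with a higher number.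

On these data alone, whether a bromo, a hydroxyl or an amine at this place would give a number near that of compound 1 or near that of compound 4 remains open. As far as these compounds go, it is also open whether the chloro change would have the same size with iodo in place of isopropyl on the aromatic carbon, as in compound 3.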